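Removing the dioxane-bearing chain from compound 2

The source may hold more compounds than are shown below. What is called first, only, known or untested is meant among the compounds shown, and "the series" means these compounds.

Compound 2 `CCN(CC)c1ccc(NC(=O)c2c(-c3c(Cl)cccc3Cl)noc2CCC2OCCCO2)c(C)c1` gives 10 nM in a functional assay on CHO K cells for inhibition of growth hormone secretagogue receptor type 1 (Homo sapiens), read by FLIPR (on this read-out higher numbers stand for weaker inhibition and lower numbers for stronger inhibition), the lowest of the two numbers measured there. Compound 3 `CCN(CC)c1ccc(NC(=O)c2c(-c3c(Cl)cccc3Cl)noc2CCC2OCCCO2)cc1` gives 14 nM, and the change a 1.4-fold higher number from compound 2 to compound 3 (0.15 log units; within the scatter) stays within the scatter. Compound 1 `CCN(CC)c1ccc(NC(=O)c2c(-c3c(Cl)cccc3Cl)noc2C)c(C(F)(F)F)c1` reaches only a limit of the assay, (the limit of > 10000 nM in this assay, at which 1 of the 3 values shown sits), at > 10000 nM. Compound 4 `CCN(CC)c1ccc(NC(=O)c2c(-c3c(Cl)cccc3Cl)noc2C)c(C)c1` differs from compound 2 by a hydrogen atom in place of a group of 7 heavy atoms (5 carbon, 2 oxygen; one six-membered non-aromatic ring with 2 hetero atoms), on a saturated chain carbon bound to an aromatic carbon. For the measured compounds named here, no measured step covers this change directly: the single measured step lies elsewhere on the molecule, and compound 1, which likewise lacks this group, differs from compound 4 in a further place as well. Because compound 1 sits at the limit of > 10000 nM in this assay, at which 1 of the 3 values shown sits, without the group, a markedly weaker inhibitor is expected. Compound 4 is therefore expected to give 1000 nM, between 100 nM and 10000 nM, a step of a 100-fold higher number from compound 2 to compound 4 (2.00 log units; beyond the scatter).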

Compound 4, half-maximal inhibitory concentration: 39 nM
Estimate against measurement, compound 4: 26-fold (1.41 log units) above; the measured number lies below the stated range.
By their numbers in this assay, from the lowest: compounds 2 and 3 (each within the scatter of the next); then compound 4. At a limit, above all of these: compound 1.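

In this assay, losing the group with the six-membered non-aromatic ring gives only a modest step, a 3.9-fold higher number from compound 2 to compound 4 (0.59 log units; beyond the scatter), so inhibition does not depend on that group. The much larger step lies at the other place, with methyl in place of trifluoromethyl on an aromatic carbon: an at least 250-fold lower number from compound 1 to compound 4 (2.40 log units; beyond the scatter). The value of compound 1 remains a limit of the assay and not a number: the limit of > 10000 nM in this assay, at which 1 of the 4 values shown sits.

The compounds shown leave open whether an amine, a carboxylic acid or a longer chain in place of the lost group would match compound 2. They also leave open how chlorine or ethyl on that aromatic carbon would compare with methyl.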